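This account rests on a few compounds, and the source may have more. Where it says the series, first, only, none or still open, it means among the compounds named here.

Compound 3 `CCN(CC)c1ccc2cc(C(=O)NO)c(=O)oc2c1` is the reference point here. In a functional assay on HCT-116 cells (Homo sapiens) for cytotoxicity, read by MTT assay, with a stated time of 72 h (on this read-out higher numbers stand for weaker inhibition and lower numbers for stronger inhibition), compound 3 gives 37600 nM, the highest of the two numbers in hand. The nearest is compound 2 `O=C(NCCNC(=O)c1cc2ccc(OCc3cccc(Br)c3)cc2oc1=O)c1cc2ccc(OCc3cccc(Br)c3)cc2oc1=O`, which gives 11600 nM in this assay; it rests on a different core, so it says little about the present change. Compound 1 `CCN(CC)c1ccc2cc(C(=O)NCCO)c(=O)oc2c1` shares the core of compound 3. In this assay compound 1 reaches only a limit of the assay, > 100000 nM. Within the data shown here, the single step measured on the amide-type nitrogen of this core, an at least 2.6-fold lower number from compound 1 to compound 3 (0.42 log units; beyond the scatter), shows that replacing one small group there by another can move the number, though its true size stays open because of the limit of > 100000 nM in this assay, at which 1 of the 3 values shown sits.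

Compound 4 `CCN(CC)c1ccc2cc(C(=O)N/N=C(/C)c3cccs3)c(=O)oc2c1` carries a much larger change at the same place: a group of 8 heavy atoms (6 carbon, 1 nitrogen, 1 sulfur; one five-membered aromatic ring with 1 hetero atom) in place of one oxygen atom, on an amide-type nitrogen. Among the measured compounds shown here, no measured pair of compounds makes this kind of exchange, so the step from compound 1 to compound 3 is the only guide, and it only shows that the site tolerates change. A modest step toward a lower number than compound 3 is expected, a 1.9-fold lower number from compound 3 to compound 4 (0.27 log units; within the scatter), with wide uncertainty. Compound 4 is therefore estimated at 20000 nM in this assay, between 5000 nM and 80000 nM.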

Compound 4, half-maximal inhibitory concentration: > 100000 nM
Compound 4 gave a limit, no number (the forecaster's own chance of this, stated with the estimate: 15%); middle value at least 5.0-fold (0.69 log units) from the limit.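

Putting the group of 8 heavy atoms, with its five-membered aromatic ring, in place of hydroxy on the amide-type nitrogen gives an at least 2.6-fold higher number from compound 3 to compound 4 (0.42 log units; beyond the scatter), so a larger group at this place on the shared core does not bring stronger inhibition. Read with the earlier step, an at least 2.6-fold lower number from compound 1 to compound 3 (0.42 log units; beyond the scatter), this leaves compound 3 as the only one of the three compounds on this core with a measured number rather than a limit in this assay, and hydroxy as the only group on this core that gives such a number. The step between compound 1 and compound 4 cannot be read, and the true size of the step from compound 3 to compound 4 stays open, because these values stop at a limit: the limit of > 100000 nM in this assay, at which 2 of the 4 values shown sit.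

The compounds shown leave open which part of the new group matters: its ring, its double bond outside the ring, or simply the absence of hydroxy. An amino group, a methoxy group or a phenyl ring at the same nitrogen could help separate these, and whether any group there can give a lower number than compound 3 remains unanswered.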